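Capping the Hydroxy Group: Compound 3 to Compound 4

The source may report more compounds than this note shows. Statements on the series, on what has been measured and on what is new or still open speak of the compounds shown alone.

Measured compounds:
Compound 1, `CC#CCN(C)Cc1cc2cc(O)ccc2n1C`: 8800 nM
Compound 2, `C#CCNCc1cc2ccccc2n1C`: 3830 nM
Compound 3, `C#CCNCc1cc2cc(O)ccc2n1C`: 8900 nM

In an assay on isolated protein for inhibition of Amine oxidase [flavin-containing] B (Rattus norvegicus) (on this read-out lower numbers stand for stronger inhibition and higher numbers for weaker inhibition), compound 3 gives the highest of the three numbers. Compound 1 sits within the scatter of it, as the step of a 1.0-fold higher number from compound 1 to compound 3 (0.00 log units; within the scatter) shows, while compound 2 sits further away: the step of a 2.3-fold higher number from compound 2 to compound 3 (0.37 log units; beyond the scatter) is modest but beyond the scatter, and it came with a hydroxy in place of hydrogen on an aromatic carbon.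

Compound 4, `C#CCNCc1cc2cc(OC)ccc2n1C`, has not been measured in this assay. It differs from compound 3 by methyl in place of hydrogen on an oxygen on an aromatic ring. Within the data shown here, no measured step involves a methoxy group, so the only bearing evidence is the step of a 2.3-fold higher number from compound 2 to compound 3 (0.37 log units; beyond the scatter), which tells how much the free hydroxy of compound 3 raised the number relative to the bare hydrogen of compound 2. Covering that hydroxy with a methyl removes the hydrogen-bond donor, and the number for compound 4 is expected to move somewhat back toward that of compound 2, a step of about a 1.5-fold lower number from compound 3 to compound 4 (0.17 log units; within the scatter). Among the measured compounds shown here, with no closer precedent, compound 4 is estimated at 6000 nM, within a range from 2500 nM to 15000 nM.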

Compound 4, inhibition constant: 4 nM
Compound 4: the middle estimate sits 1500-fold (3.18 log units) above what was measured; measured number outside the range, below it.
By their numbers in this assay, from the lowest: compound 4; then compound 2; then compounds 1 and 3 (each within the scatter of the next).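

In this assay, what the oxygen on the aromatic ring carries matters far more than the earlier compounds showed: methyl in place of hydrogen on that oxygen gives a 2200-fold lower number from compound 3 to compound 4 (3.35 log units; beyond the scatter) as a large step, whereas the hydroxy alone had shown only the modest 2.3-fold higher number from compound 2 to compound 3 (0.37 log units; beyond the scatter) in the opposite direction. The methoxy does not simply cancel that earlier step, since the methoxy gives a 960-fold lower number from compound 2 to compound 4 (2.98 log units; beyond the scatter) and so carries compound 4 far past compound 2. No measured evidence accompanies these compounds to account for a change of this size.

As far as these compounds go, it remains open whether an ethoxy group or a longer alkoxy chain would hold this level. From the compounds shown here alone, it is also open whether (but-2-yn-1-yl)(methyl)amino, within the scatter of propargylamino in the hydroxy pair, would stay so alongside the methoxy.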